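The source may report more compounds than this note shows. Statements on the series, on what has been measured and on what is new or still open speak of the compounds shown alone.

Measured so far in a functional assay on Capan-2 cells (Homo sapiens) for inhibition, read by MTT assay, with a stated time of 72 h; on this read-out lower numbers stand for stronger inhibition of growth and higher numbers for weaker inhibition of growth:
compound 1 `CC(C)(C)c1ccc(CNCCCNS(=O)(=O)c2cc(C(F)(F)F)cc(C(F)(F)F)c2)cc1` gives 2100 nM
compound 2 `O=S(=O)(NCCCNCc1ccc(C(F)(F)F)cc1)c1cc(C(F)(F)F)cc(C(F)(F)F)c1` gives 2000 nM
compound 3 `O=S(=O)(NCCCNCc1ccc(Cl)cc1)c1cc(C(F)(F)F)cc(C(F)(F)F)c1` gives 2700 nM

The three numbers sit within the usual scatter of one another; compound 3 is not set apart from compound 1 or compound 2 by any step beyond it. The steps on the benzyl aryl group, a 1.1-fold lower number from compound 1 to compound 2 (0.02 log units; within the scatter), a 1.3-fold higher number from compound 1 to compound 3 (0.11 log units; within the scatter) and a 1.4-fold higher number from compound 2 to compound 3 (0.13 log units; within the scatter), are all flat.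

Compound 4 `COc1ccccc1CNCCCNS(=O)(=O)c1cc(C(F)(F)F)cc(C(F)(F)F)c1` carries 2-methoxyphenyl in place of 4-chlorophenyl on a saturated chain carbon bound to an amine nitrogen. Going by the values given here, no measured step covers this group, but every exchange tried so far at the benzyl aryl left this assay unchanged. The expected step is therefore estimated at about a 1.2-fold lower number from compound 3 to compound 4 (0.07 log units; within the scatter), nothing beyond the scatter. Compound 4 is estimated at 2300 nM, with a range from 1000 nM to 5200 nM.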

Compound 4, concentration for 50% growth inhibition: 6000 nM
The estimate for compound 4 lay 2.6-fold (0.42 log units) below the measured number; the measured number lies above the stated range.
By their numbers in this assay, from the lowest: compounds 2, 1 and 3 (each within the scatter of the next); then compound 4.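

The benzyl aryl position is not flat after all: 2-methoxyphenyl gives a 2.2-fold higher number from compound 3 to compound 4 (0.35 log units; beyond the scatter) and a 3.0-fold higher number from compound 2 to compound 4 (0.48 log units; beyond the scatter) and a 2.9-fold higher number from compound 1 to compound 4 (0.46 log units; beyond the scatter) in this assay as steps beyond the scatter, all toward weaker inhibition of growth. Going by these compounds alone, the exchanges among 4-chlorophenyl, 4-(trifluoromethyl)phenyl and 4-(tert-butyl)phenyl stayed within the scatter, so this group is the first to separate from the others. No evidence on the origin of this shift is at hand.

On these data alone, whether the shift follows the methoxy group itself or its placement on the ring remains open. A 4-methoxyphenyl and a 2-chlorophenyl group would separate the two.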